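A few compounds are considered here, and "the series" means these few. Any claim that something is new, unique, unknown or untested is made for them only; others in the source may bear on it.

Measured in an ADME assay on Vero cells (Chlorocebus sabaeus) for cytotoxicity, read by MTT assay, with a stated time of 48 h; on this read-out lower numbers stand for stronger inhibition and higher numbers for weaker inhibition:
- Compound 1 `O=C(NC1CCC(CN2CCN(c3cc(=O)c4cc(C(F)(F)F)cc([N+](=O)[O-])c4s3)CC2)CC1)c1ccccc1`: 44.3 ug/mL
- Compound 2 `Cc1ccc(C(=O)OC2CCC(CN3CCN(c4cc(=O)c5cc(C(F)(F)F)cc([N+](=O)[O-])c5s4)CC3)CC2)cc1`: > 64 ug/mL

Compound 2 sits at a limit of the assay, not at a number: > 64 ug/mL. Compound 3 `COc1ccccc1C(=O)OC1CCC(CN2CCN(c3cc(=O)c4cc(C(F)(F)F)cc([N+](=O)[O-])c4s3)CC2)CC1` has 2-methoxyphenyl in place of 4-methylphenyl on a carbonyl carbon. For the measured compounds named here, the only measured step is an at least 1.4-fold higher number from compound 1 to compound 2 (0.15 log units; that floor lies within the scatter), and it concerns a different change, so it offers only loose guidance. Going by the values given here, no measured step tests this swap, so no shift beyond the scatter is expected in this assay. The expected step is an at least 1.0-fold lower number from compound 2 to compound 3 (0.02 log units; that floor lies within the scatter), which has no firm direction. For compound 3 the estimate is 60 ug/mL, with an expected range of 30 ug/mL to 90 ug/mL.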

Compound 3, half-maximal inhibitory concentration: > 64 ug/mL
Compound 3: a limit, no number (the forecaster's own chance of this, stated with the estimate: 60%); at least 1.0-fold (0.02 log units) between middle value and limit.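

In this assay compound 3 gives > 64 ug/mL, which is a limit and not a number. The steps between the two limits cannot be read, and no size can be given for 2-methoxyphenyl in place of 4-methylphenyl on a carbonyl carbon because of this ceiling: the limit of > 64 ug/mL in this assay, at which 2 of the 3 values shown sit.

Replacing benzamido on the saturated ring carbon with ((2-methoxyphenyl)carbonyl)oxy gives an at least 1.4-fold higher number from compound 1 to compound 3 (0.15 log units; that floor lies within the scatter), so this change is not shown to move the read-out beyond the scatter.

From the compounds shown here alone, whether any group on this carbonyl carbon can bring the read-out down to a measurable number stays open. A phenyl ring carrying an amine or a carboxylic acid would test that.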